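A few compounds are considered here, and "the series" means these few. Any claim that something is new, unique, unknown or untested is made for them only; others in the source may bear on it.

Measured compounds:
compound 1 `O=C(N/N=C\c1cn(Cc2ccc(Cl)cc2)c2cc(F)ccc12)c1c[nH]c2ccccc12` with 19500 nM
compound 2 `COc1ccc(Cn2cc(/C=N\NC(=O)c3c[nH]c4ccc(Br)cc34)c3ccc(F)cc32)cc1` with 21800 nM

Of the compounds shown here, two have been measured in a functional assay on PC-3 cells (Homo sapiens) for cytotoxicity; on this read-out lower numbers stand for stronger inhibition and higher numbers for weaker inhibition. Compound 1 `O=C(N/N=C\c1cn(Cc2ccc(Cl)cc2)c2cc(F)ccc12)c1c[nH]c2ccccc12` gives 19500 nM in this assay, and compound 2 `COc1ccc(Cn2cc(/C=N\NC(=O)c3c[nH]c4ccc(Br)cc34)c3ccc(F)cc32)cc1` gives 21800 nM. The two numbers lie within the scatter of each other, so compound 2 stands beside compound 1 with no difference that can be read as real. The two compounds differ in two places at once, so their pair tells nothing about either change on its own.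

Compound 3 `COc1ccc(Cn2cc(/C=N\NC(=O)c3c[nH]c4ccccc34)c3ccc(F)cc32)cc1` has not yet been measured. It differs from compound 2 in one place: hydrogen in place of bromo on an aromatic carbon. Among the measured compounds shown here, no measured pair shows this change by itself. Compound 1, which also carries an unsubstituted ring at this position, gives 19500 nM, a number that does not stand apart from compound 2. The expected change a 1.0-fold higher number from compound 2 to compound 3 (0.00 log units; within the scatter) is therefore small, none beyond the scatter. Compound 3 is expected to give about 22000 nM, within a range from 9000 nM to 55000 nM.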

Compound 3, half-maximal inhibitory concentration: 18400 nM
The estimate for compound 3 lay 1.2-fold (0.08 log units) above the measured number; the measured number falls inside the stated range.
By their numbers in this assay, from the lowest: compounds 3, 1 and 2 (each within the scatter of the next).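

In this assay, among the compounds shown here, the step with hydrogen in place of bromo on an aromatic carbon, on its own for the first time, reads a 1.2-fold lower number from compound 2 to compound 3 (0.07 log units; within the scatter) and lies within the scatter. Between the 5-bromo-1H-indol-3-yl and 1H-indol-3-yl groups, the assay therefore shows no difference that can be read as real. Compound 3 also isolates methoxy in place of chloro on an aromatic carbon, which reads a 1.1-fold lower number from compound 1 to compound 3 (0.03 log units; within the scatter) and likewise lies within the scatter, so neither single change separates these compounds on this read-out. Nothing available bears on why these steps stand as they do.

The compounds shown leave open whether an amine or a carboxylic acid on the indole aromatic carbon that carried bromo would give a step beyond the scatter. They also leave open whether a longer chain in place of the methoxy would do so.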